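This account rests on a few compounds, and the source may have more. Where it says the series, first, only, none or still open, it means among the compounds named here.

Compound 1 `Cc1ccc(NC(=S)Nn2c(S)nnc2-c2ccncc2)cc1` and compound 2 `S=C(Nc1ccc(Br)cc1)Nn1c(S)nnc1-c1ccncc1` are built on one core, while compound 3 `Cc1ccc(Nc2nn3c(-c4ccncc4)nnc3s2)cc1` and compound 4 `Brc1ccc(Nc2nn3c(-c4ccncc4)nnc3s2)cc1` are built on another; the difference between the two cores is not broken down here. In a functional assay on DLD-1 cells (Homo sapiens) for cytotoxicity, read by sulforhodamine B assay, with a stated time of 24 h (on this read-out higher numbers stand for weaker inhibition and lower numbers for stronger inhibition), compound 1 gives 2150 nM, and compound 2 gives 3270 nM; the change bromo in place of methyl on an aromatic carbon thus makes a 1.5-fold higher number from compound 1 to compound 2 (0.18 log units; within the scatter). In this assay compound 3 gives 1380 nM. Compound 4 carries the same change on its own core, (bromo in place of methyl on an aromatic carbon), and the surroundings of the changed carbon read the same in both pairs. Among the measured compounds shown here, the step from compound 3 to compound 4 is expected to be of similar size to the earlier one, because a 1.5-fold higher number from compound 1 to compound 2 (0.18 log units; within the scatter) is the only measured step of this kind. Compound 4 is therefore estimated at 2100 nM, between 1000 nM and 4500 nM, which means a 1.5-fold higher number from compound 3 to compound 4 (0.18 log units; within the scatter) is expected.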

Compound 4, half-maximal inhibitory concentration: 320 nM
Estimate against measurement, compound 4: 6.6-fold (0.82 log units) above; measured number below the stated range.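

In this assay, the change from 4-methylphenyl to 4-bromophenyl gives a 4.3-fold lower number from compound 3 to compound 4 (0.63 log units; beyond the scatter), so the step seen on the core of compound 1 did not carry over to the core of compound 3: the same change on two cores in this assay, a 1.5-fold higher number (0.18 log units; within the scatter) from compound 1 to compound 2 and a 4.3-fold lower number (0.63 log units; beyond the scatter) from compound 3 to compound 4, 6.6-fold (0.82 log units) apart, beyond the scatter of two such steps. For this change, then, a step measured on one core was a poor guide to the step on the other. These two pairs do not show why the cores differ, and they give no rule for other changes or other cores in the series.

The compounds shown leave open how a chloro, a methoxy or an amine at this place would behave on each core. They also leave open whether such groups would part between the two cores as methyl and bromo do.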